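Notes on a sulfonamide diamide series and one aryl swap

This account rests on a few compounds, and the source may have more. Where it says the series, first, only, none or still open, it means among the compounds named here.

Measured so far in a functional assay on IMR-32 cells (Homo sapiens) for cytotoxicity, read by MTT assay, tested at 60 ug/mL; a higher number here means more inhibition at the concentration tested (going by the name of the read-out), a lower number less inhibition:
compound 1 `CC(C)CNC(=O)CCC(NS(=O)(=O)c1cc(Cl)ccc1Cl)C(=O)NCC(C)C` gives 20.4%;
compound 2 `O=C(CCC(NS(=O)(=O)c1cc(Cl)ccc1Cl)C(=O)Nc1ccccc1)Nc1ccccc1` gives 22.9%;
compound 3 `CC(C)CNC(=O)CCC(NS(=O)(=O)c1ccc(Br)cc1)C(=O)NCC(C)C` gives 17.1%.

Compounds 1 and 3 share one core; compound 2 carries another, and the difference between the core of compound 1 and the core of compound 2 is not broken down here. All three values in this assay sit within the usual scatter of one another, so no order among them is claimed.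

Among the compounds with values here, the only change measured in one place is 4-bromophenyl in place of 2,5-dichlorophenyl on a sulfonyl sulfur. It gave a number 3.3 percentage points lower from compound 1 to compound 3 (within the scatter).

Compound 4 `O=C(CCC(NS(=O)(=O)c1ccc(Br)cc1)C(=O)Nc1ccccc1)Nc1ccccc1` is not yet measured. It differs from compound 2 by 4-bromophenyl in place of 2,5-dichlorophenyl on a sulfonyl sulfur, the same change as from compound 1 to compound 3, at the same place. In this assay, within the data shown here, the step from compound 2 to compound 4 is expected to be of similar size, a number 3.4 percentage points lower from compound 2 to compound 4 (within the scatter), because the one earlier instance a number 3.3 percentage points lower from compound 1 to compound 3 (within the scatter) lay within the scatter. Among the measured compounds shown here, that the two cores differ adds uncertainty, and only one instance of the change exists. Compound 4 is therefore estimated at 19.5%, expected to fall between 10% and 30%.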

Compound 4, a percentage reported as inhibition, at one concentration (the size of the read-out at that concentration, not a potency): 10%
Estimate against measurement, compound 4: 9.5 percentage points above; the measured number falls inside the stated range.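

In this assay, 4-bromophenyl in place of 2,5-dichlorophenyl on a sulfonyl sulfur gives a number 12.9 percentage points lower from compound 2 to compound 4 (beyond the scatter). Compared with the earlier instance of the same change, the two steps cannot be told apart: the same change on two cores in this assay, a number 3.3 percentage points lower (within the scatter) from compound 1 to compound 3 and a number 12.9 percentage points lower (beyond the scatter) from compound 2 to compound 4, 9.6 percentage points apart, within the scatter of two such steps. Within the data shown here, the data therefore give no ground for saying that the core alters the size of this step, but with one pair on each core they do not show that the size carries over either, and only the step on the core of compound 2 lies beyond the scatter.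

Still open, going by these compounds, is how other groups on the sulfonyl sulfur behave, such as a plain phenyl or a methoxy-bearing phenyl, which could show whether the step follows the bromine or the loss of the two chlorines. Also open, on these data alone, is whether the step holds on cores whose amide ends carry an amine, a carboxylic acid or a longer chain.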